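This account rests on a few compounds, and the source may have more. Where it says the series, first, only, none or still open, it means among the compounds named here.

Notes on the series. In a functional assay on MDA-MB-231 cells for antagonist activity at C-X-C chemokine receptor type 4 (Homo sapiens), tested at 10 nM (a lower number here means a weaker effect, a higher number a stronger effect of the compound at the concentration tested), compound 3 `Fc1cnc(NCc2ccc(CNc3nccc(C(F)(F)F)n3)cc2)nc1` gives 73%, the second highest of the three numbers in hand. Compound 2 `Fc1cnc(NCc2ccc(CNc3ncc(F)cn3)cc2)nc1` sits nearest at 75%, a gap that lies within the scatter of repeated measurements. Compound 1 `c1cnc(NCc2ccc(CNc3ccc(N4CCCC4)cc3)cc2)nc1` is furthest away at 57%, a gap beyond the scatter. Compounds 2 and 3 carry different substituents on the shared core and still read alike, so the numbers in hand give no sign that this position moves the read-out.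

The next compound, compound 4 `CSc1ccnc(NCc2ccc(CNc3ncc(F)cn3)cc2)n1`, differs from compound 3 in one place: methylsulfanyl in place of trifluoromethyl on an aromatic carbon. Within the data shown here, no measured pair covers a change of this kind, so nothing beyond the closeness of compound 2 and compound 3 informs the expectation.

The step of a number 5 percentage points lower from compound 3 to compound 4 (within the scatter) is expected to be small, with no direction beyond the scatter. Compound 4 is therefore estimated at 68%, with a plausible range from 50% to 85%.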

Compound 4, a percentage reported as inhibition, at one concentration (the size of the read-out at that concentration, not a potency): 62%
Beside the measured number, compound 4's estimate is 6 percentage points above it; measured number inside the range.
By their numbers in this assay, from the lowest: compounds 1 and 4 (each within the scatter of the next); then compounds 3 and 2 (each within the scatter of the next).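

In this assay, the group on this aromatic carbon, next to the ring nitrogen, does move the read-out, which the close reading of compounds 2 and 3 gave no sign of. Methylsulfanyl in place of trifluoromethyl gives a number 11 percentage points lower from compound 3 to compound 4 (beyond the scatter), and 4-(methylsulfanyl)pyrimidin-2-yl in place of 5-fluoropyrimidin-2-yl on an amine nitrogen gives a number 13 percentage points lower from compound 2 to compound 4 (beyond the scatter), so both steps to methylsulfanyl run the same way and are modest in size. No measurement in hand speaks to what lies behind these steps.

Still open, from the compounds shown here alone, is how an amine or a methoxy group on the same aromatic carbon would read. Also open, going by these compounds, is whether a longer chain on the sulfur would lower the read-out further or restore it.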